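Tosyloxy for methoxyphenyl on the fused core

The compounds below may be only part of what the source reports. "The series", "measured", "known", "first", "only" and "open" are said of these compounds alone.

For the measured compounds named here, compound 1 `N#Cc1ccn2c(-c3ccccc3)c(-c3ccccc3)c(Cc3ccccc3)c2c1` is the only member of this set with a number: in an assay for inhibition of Polyunsaturated fatty acid lipoxygenase ALOX15 (Oryctolagus cuniculus) (on this read-out higher numbers stand for weaker inhibition and lower numbers for stronger inhibition), compound 1 gives 46000 nM, a weak result. Compound 2 `COc1ccccc1-c1c(-c2ccccc2)c(-c2ccccc2)n2ccc(C#N)cc12` carries the same fused core, the same pair of phenyl groups and the same nitrile, but in this assay compound 2 gives "not determined" (no result reported), so compound 2 stands nowhere on the numbers; the comparison of compound 2 with compound 1 cannot be drawn from the data.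

Compound 3 `Cc1ccc(S(=O)(=O)Oc2c(-c3ccccc3)c(-c3ccccc3)n3ccc(C#N)cc23)cc1` differs from compound 2 in one place: ((4-methylphenyl)sulfonyl)oxy in place of 2-methoxyphenyl on an aromatic carbon. Going by the values given here, no step between measured compounds frames this change, and the only anchor is the weak reading of compound 1. On that basis compound 3 is expected to stay in the weak range in this assay, with no direction of the step beyond the scatter that can be claimed; a shift either way of modest size would not be surprising. The estimate for compound 3 in this assay is 35000 nM, with a range from 6000 nM to 200000 nM, and a real chance that only a limit is reported.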

Compound 3, half-maximal inhibitory concentration: 25000 nM
The estimate for compound 3 lay 1.4-fold (0.15 log units) above the measured number; measured number inside the range.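

In this assay, ((4-methylphenyl)sulfonyl)oxy in place of benzyl on an aromatic carbon of the five-membered aromatic ring gives a 1.8-fold lower number from compound 1 to compound 3 (0.26 log units; within the scatter), so the two groups cannot be told apart on this read-out. This position, two ring bonds from the ring nitrogen, now has readings for two quite different groups, a sulfonate-linked aryl group and a carbon-linked one: compound 1 gives 46000 nM and compound 3 gives 25000 nM, both weak, while the step from compound 2 to compound 3 cannot be read, as compound 2 has no number. No measurement on the series offers an explanation for this similarity of the two readings.

Still open, as far as these compounds go, is whether any group at this position can move the reading beyond the scatter, for example a primary amine, a carboxylic acid or a longer alkyl chain in place of ((4-methylphenyl)sulfonyl)oxy. The compounds shown also leave open whether 2-methoxyphenyl at this position falls in the same weak range, and what replacing the shared nitrile with an amide or a carboxylic acid would do in this assay.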